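Pyridinylmethyl Amide in Place of Fluorophenyl

A few compounds are considered here, and "the series" means these few. Any claim that something is new, unique, unknown or untested is made for them only; others in the source may bear on it.

Among the compounds with values here, compound 3 `Cc1cc(C(=O)Nc2ccc(F)cc2)nn1Cc1cc(Cl)ccc1OCc1ccccc1` gives 79.4 nM in an assay on CHO-K1 cells for displacement of a labelled ligand from prostaglandin E2 receptor EP1 subtype (Homo sapiens) (on this read-out higher numbers stand for weaker inhibition and lower numbers for stronger inhibition), the lowest of the three numbers measured so far; compound 1 `Cc1cc(C(=O)NC(C)C)nn1Cc1cc(Cl)ccc1OCc1ccccc1` gives 126 nM and compound 2 `Cc1cc(C(=O)Nc2cccc(F)c2)nn1Cc1cc(Cl)ccc1OCc1ccccc1` gives 200 nM. The step of a 1.6-fold lower number from compound 1 to compound 3 (0.20 log units; within the scatter) lies within the scatter, whereas a 2.5-fold lower number from compound 2 to compound 3 (0.40 log units; beyond the scatter) is modest but beyond it. Compound 4 `Cc1cc(C(=O)NCc2ccccn2)nn1Cc1cc(Cl)ccc1OCc1ccccc1` differs from compound 3 by (pyridin-2-yl)methyl in place of 4-fluorophenyl on an amide-type nitrogen. Within the data shown here, no measured step covers this exact exchange, yet the three amide substituents seen so far sit within a narrow band, so only a small step is expected: a 1.6-fold higher number from compound 3 to compound 4 (0.21 log units; within the scatter), a somewhat higher number in this assay. Compound 4 is accordingly estimated at 130 nM, with a range from 50 nM to 350 nM.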

Compound 4, half-maximal inhibitory concentration: 25.1 nM
The estimate for compound 4 lay 5.2-fold (0.71 log units) above the measured number; measured number outside the range, below it.
By their numbers in this assay, from the lowest: compound 4; then compounds 3, 1 and 2 (each within the scatter of the next, the first and the last beyond it).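

With (pyridin-2-yl)methyl on the amide-type nitrogen, the number falls clearly below the narrow band of the earlier substituents: a 3.2-fold lower number from compound 3 to compound 4 (0.50 log units; beyond the scatter) and a 5.0-fold lower number from compound 1 to compound 4 (0.70 log units; beyond the scatter) and also an 8.0-fold lower number from compound 2 to compound 4 (0.90 log units; beyond the scatter) all lie beyond the scatter, making compound 4 the strongest inhibitor of the four. This exchange changes the ring and its link to the nitrogen at once, so the two changes cannot be separated. No evidence at hand accounts for the gain. Still open, going by these compounds, is whether benzyl, with a carbon-only ring, would keep this gain, and whether (pyridin-3-yl)methyl, (pyridin-4-yl)methyl or the longer 2-(pyridin-2-yl)ethyl would match it.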